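Ortho cyano in place of ortho chloro on the N-methyl series

The source may hold more compounds than are shown below. What is called first, only, known or untested is meant among the compounds shown, and "the series" means these compounds.

Compound 2 `CC(=O)/C(=N\Nc1ccccc1Cl)N(C)c1cccc(Cl)c1` gives > 10000 nM in an assay on isolated protein for binding affinity to corticotropin-releasing factor receptor 1 (Homo sapiens) (a higher number here means a weaker inhibitor, a lower number a stronger inhibitor), which is a limit of this assay and not a number. Compound 1 `CC(=O)/C(=N\Nc1ccccc1)N(C)c1cccc(Cl)c1` likewise gives > 10000 nM, also a limit. The step that the two limits leave unreadable from compound 1 to compound 2 therefore cannot be read, as the limit of > 10000 nM in this assay, at which 2 of the 3 values shown sit, shows. Compound 3 `CC(=O)/C(=N\Nc1ccccc1C#N)Nc1cccc(Cl)c1` carries the same cyano group without the methyl and gives 415 nM; 415 nM (2 entries) in this assay. The change to compound 4 `CC(=O)/C(=N\Nc1ccccc1C#N)N(C)c1cccc(Cl)c1` is cyano in place of chloro on an aromatic carbon. Among the compounds with values here, no measured step reads on this change; the only step in the set, from a limit to a limit, gives no size. The step of an at least 3.3-fold lower number from compound 2 to compound 4 (0.52 log units; beyond the scatter) is therefore an estimate starting from a limit. Compound 4 is expected at 3000 nM, within 700 nM to 15000 nM.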

Compound 4, inhibition constant: > 10000 nM
Compound 4: no number, only a limit (the forecaster's own chance of this, stated with the estimate: 40%); middle value at least 3.3-fold (0.52 log units) away from the limit.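

Compound 4 gives > 10000 nM in this assay, which is a limit and not a number. Within the data shown here, no step among compound 1, compound 2 and compound 4 can be read. Left open is whether hydrogen, chloro and cyano differ at all on the N-methyl series.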